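The compounds below may be only part of what the source reports. "The series", "measured", "known", "first", "only" and "open" are said of these compounds alone.

Working notes on the nitroxide-bearing series. The shared core carries, on its aromatic ring, an ether-linked side chain ending in an amino acid fragment. Compound 1 `CC1(C)N(O)C(c2ccc(OCC(=O)N[C@@H](CCCNC(=N)N)C(=O)O)cc2)=[N+]([O-])C1(C)C` gives 92900 nM in a functional assay on PC-12 cells (Rattus norvegicus) for inhibition, read by MTT assay; on this read-out lower numbers stand for an effect already at smaller amounts and higher numbers for an effect only at larger amounts of compound. Compound 2 `COC(=O)[C@@H](N)CCCNC(=N)NC(=O)COc1ccc(C2=NC(C)(C)C(C)(C)N2O)cc1` gives 93600 nM in this assay. Compound 3 `COC(=O)[C@@H](N)CC(=O)NCCOc1ccc(C2=[N+]([O-])C(C)(C)C(C)(C)N2O)cc1` gives 39000 nM in this assay, the lowest of the three numbers; compound 1 and compound 2 both lie beyond the usual scatter from it, so compound 3 stands as the most potent of the measured set.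

Compound 4 `CC1(C)N(O)C(c2ccc(OCCNC(=O)CC[C@H](N)C(=O)O)cc2)=[N+]([O-])C1(C)C` has not yet been measured. It differs from compound 3 only in how the same atoms are joined: 2-amino-2-carboxyethyl in place of amino(methoxycarbonyl)methyl on a saturated chain carbon bound to a carbonyl carbon. In practical terms the amide is turned around and the ester becomes a free acid, while the overall size of the side chain is unchanged. For the measured compounds named here, no step between two measured compounds tracks this change, and compound 1 and compound 2, which differ elsewhere as well, give no usable guide.

Given that, no step beyond the scatter is expected in this assay going a 1.3-fold higher number from compound 3 to compound 4 (0.11 log units; within the scatter); compound 4 is expected at about 50000 nM, within a range of 20000 nM to 130000 nM.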

Compound 4, half-maximal effective concentration: 41800 nM
Beside the measured number, compound 4's estimate is 1.2-fold (0.08 log units) above it; measured number inside the range.
By their numbers in this assay, from the lowest: compounds 3 and 4 (each within the scatter of the next); then compounds 1 and 2 (each within the scatter of the next).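

The step on a saturated chain carbon bound to a carbonyl carbon, 2-amino-2-carboxyethyl in place of amino(methoxycarbonyl)methyl, reads a 1.1-fold higher number from compound 3 to compound 4 (0.03 log units; within the scatter) in this assay. For the compounds shown here, this is the first readable step, and it shows that this same-atom rearrangement, which turns the amide around and exchanges the methyl ester for a free carboxylic acid, does not separate the two compounds beyond the scatter. No measurement on hand bears on why the two compounds fall so close together.

On these data alone, the amide orientation and the ester-to-acid exchange travel together in this single step, so their separate contributions remain open, and they could be offsetting or both negligible. As far as these compounds go, how this position responds to a primary carboxamide at the chain end, or to a longer chain, also remains open.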